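Carboxy to five-membered ring on the shared core

The source may hold more compounds than are shown below. What is called first, only, known or untested is meant among the compounds shown, and "the series" means these compounds.

The three measured compounds share the core of compound 1 `O=C(O)c1cc(=O)c2ccc(OCCCN3CCC(=C(c4ccccc4)c4ccccc4)CC3)cc2o1` and differ only in the linking unit between the piperidine and the two phenyl rings. In a functional assay (ileum) with Cavia porcellus as the target (on this read-out lower numbers stand for stronger inhibition and higher numbers for weaker inhibition), compound 1 gives 16.2 nM, the highest of the three numbers. Compound 2 `O=C(O)c1cc(=O)c2ccc(OCCCN3CCC(C(O)(c4ccccc4)c4ccccc4)CC3)cc2o1` gives 5.25 nM in this assay, a lower number than compound 1 and beyond the usual scatter. Compound 3 `O=C(O)c1cc(=O)c2ccc(OCCCN3CCC(OC(c4ccccc4)c4ccccc4)CC3)cc2o1` gives 9.12 nM in this assay; the gap between compound 3 and compound 1 is within the scatter, so the two cannot be ordered.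

Compound 4 `O=c1cc(C2N=NN=N2)oc2cc(OCCCN3CCC(=C(c4ccccc4)c4ccccc4)CC3)ccc12` is not yet measured. It keeps the linking unit of compound 1 and changes the acid end: a group of 5 heavy atoms (1 carbon, 4 nitrogen; one five-membered non-aromatic ring with 4 hetero atoms) in place of a group of 3 heavy atoms (1 carbon, 2 oxygen; no ring), on an aromatic carbon. Going by the values given here, no measured pair in this set shows this exchange, so its effect in this assay has no direct precedent here. The expected step is small: the number for compound 4 is estimated to lie close to that of compound 1, if anything a little lower, with the step from compound 1 to compound 4 a 1.6-fold lower number from compound 1 to compound 4 (0.21 log units; within the scatter) expected to stay within the scatter. For compound 4 the estimate in this assay is 10 nM, with a range from 3 nM to 35 nM.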

Compound 4, antagonist equilibrium constant: 3.63 nM
Compound 4: middle estimate off by 2.8-fold (0.44 log units), on the high side; the measured number falls inside the stated range.
By their numbers in this assay, from the lowest: compounds 4, 2, 3 and 1 (each within the scatter of the next, the first and the last beyond it).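

With the linking unit of compound 1 held fixed, the exchange of carboxy for the five-membered non-aromatic ring with 4 hetero atoms, on the aromatic carbon next to the ring oxygen, gives a 4.5-fold lower number from compound 1 to compound 4 (0.65 log units; beyond the scatter) in this assay. Going by these compounds alone, this is the first one-place comparison, and it shows that on this linking unit the position does not need carboxy for a low number: the entering group, with 0 hydrogen-bond donors and 4 hydrogen-bond acceptors in place of 1 of each, gives a lower number beyond the scatter. No measurement here accounts for the size or direction of this step.

Going by these compounds, it remains open whether the same exchange lowers the number on the linking units of compound 2 and compound 3, since this single pair speaks only for the linking unit of compound 1. Also open, on these data alone, is how other groups at this position would read in this assay, such as a methyl ester, a primary amide or a nitrile, and whether the acid end can be left as a bare hydrogen.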